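A New Ring on the Chain of Compound 1

The source may hold more compounds than are shown below. What is called first, only, known or untested is meant among the compounds shown, and "the series" means these compounds.

Compound 1 `COc1cc(/C=C2\C(=O)Nc3ccc(Cl)cc32)ccc1OCCCN1CC(C)OC(C)C1` gives 2710 nM (a number)
Compound 2 `COc1cc(/C=C2\C(=O)Nc3ccc(C)cc32)ccc1OCCCN1CC(C)OC(C)C1` gives > 20000 nM (a limit)
Compound 3 `COc1cc(/C=C2\C(=O)Nc3ccccc32)ccc1OCCCN1CCN(c2ncccc2C(F)(F)F)CC1` gives > 20000 nM (a limit)

In a functional assay on DU-145 cells (Homo sapiens) for cytotoxicity, read by MTT assay, with a stated time of 48 h (on this read-out lower numbers stand for stronger inhibition and higher numbers for weaker inhibition), compound 1 gives 2710 nM and is the only one of the three with an actual number. Compound 2 has only a limit of the assay, > 20000 nM, and no number. Compound 3 likewise has only a limit, > 20000 nM, and no number.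

For the measured compounds named here, the only measured step is an at least 7.3-fold higher number from compound 1 to compound 2 (0.86 log units; beyond the scatter), with methyl in place of chloro on an aromatic carbon. Compound 4 `COc1cc(/C=C2\C(=O)Nc3ccc(Cl)cc32)ccc1OCCCN1CCN(C)CC1` keeps the chloro of compound 1 and changes a different group: 4-methylpiperazin-1-yl in place of 2,6-dimethylmorpholin-4-yl on a saturated chain carbon, three bonds along the chain from an oxygen on an aromatic ring, on a saturated chain carbon, three bonds along the chain from an oxygen on an aromatic ring. Going by the values given here, no measured step touches this group, so the size of the change remains uncertain. Among the compounds with values here, compound 2 shows only that one swap can move the number beyond the scatter, as in an at least 7.3-fold higher number from compound 1 to compound 2 (0.86 log units; beyond the scatter), so the range has to be wide.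

Compound 2 and compound 3 lean the expectation towards a higher number because of the limit of > 20000 nM in this assay, at which 2 of the 3 values shown sit, but only modestly. The expected change is a 1.7-fold higher number from compound 1 to compound 4 (0.22 log units; within the scatter), which is small and uncertain. For compound 4 the estimate is 4500 nM, with an expected range from 1300 nM to 16000 nM.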

Compound 4, half-maximal inhibitory concentration: 2150 nM
Estimate against measurement, compound 4: 2.1-fold (0.32 log units) above; low and high end bracket the measured number.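

For the compounds shown here, putting 4-methylpiperazin-1-yl in place of 2,6-dimethylmorpholin-4-yl on the saturated chain carbon gives a 1.3-fold lower number from compound 1 to compound 4 (0.10 log units; within the scatter) in this assay, the first measured step at this end of the chain. With the chloro kept, the two rings therefore cannot be told apart in this assay, even though one carries a second nitrogen where the other carries an oxygen and their methyl groups differ. Compound 4 also adds a second actual number to a small set in which the limit remains just as common: the limit of > 20000 nM in this assay, at which 2 of the 4 values shown sit.

The compounds shown leave open whether other groups at the end of the chain, such as a piperidine, a dimethylamino group or a morpholine without its methyl groups, would also fit this pattern, and whether a longer chain would change the number. On these data alone, it also remains open whether 4-methylpiperazin-1-yl would give a measurable number with methyl in place of chloro on the core, or how a fluoro or bromo group in place of the chloro would behave with either ring.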